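Cyclohexyl to tert-butyl: working notes on the series

This account rests on a few compounds, and the source may have more. Where it says the series, first, only, none or still open, it means among the compounds named here.

compound 1 `CCNC(=O)Nc1sc2ccccc2c1C(=O)N1CCN(C2CCN(C(C)=O)CC2)CC1` gives "not determined" (no result reported)
compound 2 `CCCCC(=O)N1CCC(N2CCN(C(=O)c3c(NC(=O)NCC)sc4ccccc34)CC2)CC1` gives "not determined" (no result reported)
compound 3 `CCNC(=O)Nc1sc2ccccc2c1C(=O)N1CCN(C2CCN(C(=O)C3CCCCC3)CC2)CC1` gives 146 nM
compound 4 `CCNC(=O)Nc1sc2ccccc2c1C(=O)N1CCN(C2CCN(C(=O)C(C)(C)C)CC2)CC1` is not yet measured

These entries all refer to a functional assay on HepG2 cells (Homo sapiens) for inhibition, read by scintillation counting, with a stated time of 2 h (a lower number here means a stronger inhibitor, a higher number a weaker inhibitor), and compound 3 alone has a number there, so it cannot be ranked against any other compound. Among the compounds with values here, compound 4 carries tert-butyl in place of cyclohexyl on a carbonyl carbon, next to the amide-type nitrogen in a ring as the only other neighbour of that carbon: tert-butyl in place of cyclohexyl on a carbonyl carbon. Within the data shown here, no measured pair shows what a change at this place does, so neither the size nor the direction of the step is supported by data. The expectation rests on compound 3 at 146 nM and on the structural change alone. A small loss is expected in this assay, and the estimated change a 1.7-fold higher number from compound 3 to compound 4 (0.23 log units; within the scatter) stays close to the usual scatter. For compound 4 the estimated value is 250 nM, with an expected range from 70 nM to 900 nM in this wide, single-reference estimate.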

Compound 4, half-maximal inhibitory concentration: 450 nM
Compound 4: the middle estimate sits 1.8-fold (0.26 log units) below what was measured; measured number inside the range.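

In this assay, within the data shown here, the change from cyclohexyl to tert-butyl on the carbonyl carbon gives a 3.1-fold higher number from compound 3 to compound 4 (0.49 log units; beyond the scatter), the first readable step at this place. The group on this carbonyl therefore affects the read-out, and this single pair favours cyclohexyl over tert-butyl, though it cannot separate the loss of the ring from the drop in heavy atoms. No measurement shown here bears on the reason for the step.

The steps involving compound 1 and compound 2 cannot be read, leaving the trend across the acyl groups on this nitrogen undefined. Also open, from the compounds shown here alone, is how a phenyl ring or a cyclopropyl group on the same carbonyl carbon would compare, and whether a ring of any kind at this place tracks with the lower number seen for compound 3.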